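The compounds below may be only part of what the source reports. "The series", "measured", "known", "first", "only" and "open" are said of these compounds alone.

Measured so far:
compound 1 `CC1(O)CCCN(S(=O)(=O)c2cc(C(=O)Nc3ccc(F)c(Cl)c3)ccc2F)CC1` — 11000 nM
compound 2 `O=C(Nc1ccc(F)c(Cl)c1)c1ccc(F)c(S(=O)(=O)N2C[C@H](O)CC[C@H](O)C2)c1` — 25500 nM
compound 3 `CN1CCN(S(=O)(=O)c2cc(C(=O)Nc3ccc(F)c(Cl)c3)ccc2F)CC(O)C1` — 31000 nM

In an ADME assay on HepG2 2.2.15 cells (Homo sapiens) for cytotoxicity, read by luminescence, with a stated time of 3 days (a higher number here means that more compound is tolerated, a lower number that less compound is tolerated), compound 3 gives 31000 nM, the highest of the three numbers; its gap to compound 2 is within the scatter (a 1.2-fold higher number from compound 2 to compound 3 (0.08 log units; within the scatter)), and only the gap from compound 1 lies beyond it (a 2.8-fold higher number from compound 1 to compound 3 (0.45 log units; beyond the scatter)). Compound 4 `CC1(O)CCCCN(S(=O)(=O)c2cc(C(=O)Nc3ccc(F)c(Cl)c3)ccc2F)C1` carries a single change on the shared core: 3-hydroxy-3-methylazepan-1-yl in place of 6-hydroxy-4-methyl-1,4-diazepan-1-yl on a sulfonyl sulfur. The entering ring resembles that of compound 1, so the step that bears most on this change is a 2.8-fold higher number from compound 1 to compound 3 (0.45 log units; beyond the scatter), with a 2.3-fold higher number from compound 1 to compound 2 (0.37 log units; beyond the scatter) pointing the same way. A modest step downward is therefore expected, roughly undoing that earlier rise: a 2.2-fold lower number from compound 3 to compound 4 (0.35 log units; beyond the scatter). Compound 4 is estimated at 14000 nM, with a range from 7000 nM to 28000 nM, because compound 1 gives 11000 nM.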

Compound 4, half-maximal cytotoxic concentration: 10000 nM
Compound 4: the middle estimate sits 1.4-fold (0.15 log units) above what was measured; the measured number falls inside the stated range.
By their numbers in this assay, from the lowest: compounds 4 and 1 (each within the scatter of the next); then compounds 2 and 3 (each within the scatter of the next).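

In this assay, the 3-hydroxy-3-methylazepan-1-yl and 4-hydroxy-4-methylazepan-1-yl groups on the sulfonyl sulfur cannot be told apart (a 1.1-fold lower number from compound 1 to compound 4 (0.04 log units; within the scatter)), so the placing of the hydroxy and methyl groups on this azepane ring shows no clear effect here. Against the 6-hydroxy-4-methyl-1,4-diazepan-1-yl ring the new group gives a modest drop (a 3.1-fold lower number from compound 3 to compound 4 (0.49 log units; beyond the scatter)), and against the 3,6-dihydroxyazepan-1-yl ring a similar one (a 2.6-fold lower number from compound 2 to compound 4 (0.41 log units; beyond the scatter)). No measurement explains these gaps. Open, on these data alone, is how an azepane ring carrying a carboxylic acid or a primary amine would compare.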